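Amide variation on the naphthyl-pyridyl acrylamide series

The compounds below may be only part of what the source reports. "The series", "measured", "known", "first", "only" and "open" are said of these compounds alone.

Measured so far:
compound 1 `O=C(O)CCNC(=O)/C=C/c1ccncc1-c1ccc2ccccc2c1` — 870 nM
compound 2 `CC(C)[C@@H](NC(=O)/C=C/c1ccncc1-c1ccc2ccccc2c1)C(=O)O` — "not determined" (no result reported)

In an assay on a protein complex for inhibition of CDK8/Cyclin C (Homo sapiens), with a stated time of 1 h (a lower number here means a stronger inhibitor, a higher number a weaker inhibitor), compound 1 gives 870 nM. Going by the values given here, compound 2 `CC(C)[C@@H](NC(=O)/C=C/c1ccncc1-c1ccc2ccccc2c1)C(=O)O` carries a (1-carboxy-2-methylpropyl)amino group on the amide carbonyl and was not assigned a number in this assay; its entry reads "not determined" (no result reported), so compound 2 stands nowhere on the scale at present and no step can be sized from it.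

The next compound follows from compound 2 by one change at the carbonyl carbon: dimethylamino in place of (1-carboxy-2-methylpropyl)amino on a carbonyl carbon. That gives compound 3 `CN(C)C(=O)/C=C/c1ccncc1-c1ccc2ccccc2c1`, still to be measured in this assay.

With compound 2 lacking a number, neither the direction nor the size of the step from compound 2 to compound 3 can be fixed from the record. Among the compounds with values here, the only anchor is compound 1 with 870 nM, which shares the core and differs from compound 3 only at the amide substituent. On that basis compound 3 is expected to land in the same broad region, with the estimate set at 1500 nM and the range 300 nM to 8000 nM. On these data alone, whether the dimethylamino variant reads inside or outside the scatter around compound 1 remains open until the value is in hand.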

Compound 3, half-maximal inhibitory concentration: 30.1 nM
The estimate for compound 3 lay 50-fold (1.70 log units) above the measured number; measured number below the stated range.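

In this assay, dimethylamino in place of (2-carboxyethyl)amino on a carbonyl carbon gives a 29-fold lower number from compound 1 to compound 3 (1.46 log units; beyond the scatter), so this one position can move the reading well beyond the scatter. The carboxylic acid of compound 1 is therefore not required for inhibition in this series: compound 3 has no acid on this carbonyl carbon, and its dimethylamino group carries 0 hydrogen-bond donors, yet it has the lower number of the pair. The step from compound 2 to compound 3 cannot be read, as compound 2 has no number, and nothing on hand accounts for the size of the step from compound 1 to compound 3.

On these data alone, the change from compound 1 to compound 3 removes both the carboxylic acid and the amide hydrogen, so it remains open which of the two goes with the lower number; a methylamino group or a plain ethylamino chain would separate them. Also open, as far as these compounds go, is how the position responds to diethylamino, to a morpholine amide or to a chain ending in an amine.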